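Compound 3 to compound 4: hydroxy placement on the ring

This account rests on a few compounds, and the source may have more. Where it says the series, first, only, none or still open, it means among the compounds named here.

Compound 1 `CC1=CC[C@H](C(C)(C)NC(=S)N/N=C/c2ccccc2)CC1` carries an unsubstituted phenyl on the carbon with a double bond to nitrogen; in a functional assay on NCI-H460 cells (Homo sapiens) for inhibition, read by sulforhodamine B assay, with a stated time of 48 h (on this read-out lower numbers stand for stronger inhibition of growth and higher numbers for weaker inhibition of growth), compound 1 gives 53900 nM. Compound 2 `COc1ccc(/C=N/NC(=S)NC(C)(C)[C@H]2CC=C(C)CC2)cc1` adds a methoxy on an aromatic carbon and in this assay gives 47800 nM, a change of a 1.1-fold lower number from compound 1 to compound 2 (0.05 log units; within the scatter). Compound 3 `CC1=CC[C@H](C(C)(C)NC(=S)N/N=C/c2ccc(O)cc2)CC1` bears a hydroxy on an aromatic carbon instead. Compound 3 reaches only the limit of this assay, > 100000 nM, which is the limit of > 100000 nM in this assay, at which 1 of the 3 values shown sits. The steps of an at least 1.8-fold higher number from compound 1 to compound 3 (0.26 log units; that floor lies within the scatter) and an at least 2.0-fold higher number from compound 2 to compound 3 (0.32 log units; beyond the scatter) thus rest on a floor rather than a number, and compound 3 is the only one of the three standing at that limit.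

Compound 4 `CC1=CC[C@H](C(C)(C)NC(=S)N/N=C/c2ccccc2O)CC1` differs from compound 3 by 2-hydroxyphenyl in place of 4-hydroxyphenyl on a carbon with a double bond to nitrogen. For the measured compounds named here, no measured step moves the hydroxy from one aromatic carbon to another; the steps that touch the hydroxy, an at least 1.8-fold higher number from compound 1 to compound 3 (0.26 log units; that floor lies within the scatter) and an at least 2.0-fold higher number from compound 2 to compound 3 (0.32 log units; beyond the scatter), only place compound 3 at or beyond the floor. In this assay compound 4 is therefore expected to remain near that floor, with an expected step of a number no higher from compound 3 to compound 4 (the limit leaves the size open) that cannot be resolved against a limit. The estimate for compound 4 in this assay is 100000 nM, with a range from 40000 nM to 250000 nM, and a fair chance that only a limit is reported again.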

Compound 4, concentration for total growth inhibition: 8400 nM
Beside the measured number, compound 4's estimate is 12-fold (1.08 log units) above it; the measured number lies below the stated range.
By their numbers in this assay, from the lowest: compound 4; then compounds 2 and 1 (each within the scatter of the next). At a limit, above all of these: compound 3.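

For the compounds shown here, the two compounds have the same atoms, joined differently: in this assay, 2-hydroxyphenyl in place of 4-hydroxyphenyl on the carbon with a double bond to nitrogen gives an at least 11-fold lower number from compound 3 to compound 4 (1.07 log units; beyond the scatter), the first step that rests on where the hydroxy sits. That step is a floor and not a size, as the value of compound 3 is a limit: the limit of > 100000 nM in this assay, at which 1 of the 4 values shown sits.

Against the unsubstituted phenyl, the 2-hydroxyphenyl gives a 6.4-fold lower number from compound 1 to compound 4 (0.81 log units; beyond the scatter), and in place of 4-methoxyphenyl it gives a 5.7-fold lower number from compound 2 to compound 4 (0.76 log units; beyond the scatter), so compound 4 is the only one of the series with a number clearly lower than the others, and compound 3 shows that a hydroxy alone does not bring this.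

Going by these compounds, whether the gain belongs to the hydroxy itself or would hold for an amine or a carboxylic acid in the same place stays open. On these data alone, the true size of the step from compound 3 also stays open, with no number for that compound.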